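Replacing a Methylethenyl Group with Methoxy on a Shared Core

The source may hold more compounds than are shown below. What is called first, only, known or untested is meant among the compounds shown, and "the series" means these compounds.

Of the compounds shown here, two sharing one core have been tested in an assay on isolated protein for inhibition of tyrosine-protein kinase receptor UFO (Homo sapiens), read by FRET and Z'-LYTE, with a stated time of 1.5 h; on this read-out higher numbers stand for weaker inhibition and lower numbers for stronger inhibition. Compound 1 `CCc1ccc2c(c1)c(=O)c(C(=O)Nc1ccc(Oc3ncnc4[nH]cc(-c5ccccc5)c34)c(F)c1)c(C)n2C` gives 6 nM in this assay. For the measured compounds named here, compound 2 `C=C(C)c1ccc2c(c1)c(=O)c(C(=O)Nc1ccc(Oc3ncnc4[nH]cc(-c5ccccc5)c34)c(F)c1)c(C)n2C` gives 170 nM in this assay, which is the higher of the two numbers measured so far. Going by the values given here, the single measured step between them, a 28-fold higher number from compound 1 to compound 2 (1.45 log units; beyond the scatter), comes from exchanging ethyl for 1-methylethenyl at one aromatic carbon, and it is a large move in the direction of weaker inhibition.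

Compound 3 `COc1ccc2c(c1)c(=O)c(C(=O)Nc1ccc(Oc3ncnc4[nH]cc(-c5ccccc5)c34)c(F)c1)c(C)n2C` has not yet been measured. It differs from compound 2 in one place: methoxy in place of 1-methylethenyl on an aromatic carbon. Among the compounds with values here, the only measured step that touches this position is a 28-fold higher number from compound 1 to compound 2 (1.45 log units; beyond the scatter), where ethyl stood at the same aromatic carbon. Methoxy is neither ethyl nor 1-methylethenyl, so the data give no direct comparison for it, and the expectation for compound 3 rests on that one step alone. The step from compound 2 to compound 3 is expected to move back toward stronger inhibition, with a 6.8-fold lower number from compound 2 to compound 3 (0.83 log units; beyond the scatter). Compound 3 is thus estimated at 25 nM in this assay, with a range from 5 nM to 130 nM.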

Compound 3, half-maximal inhibitory concentration: 99 nM
Estimate against measurement, compound 3: 4.0-fold (0.60 log units) below, and the stated range covers the measured number.
By their numbers in this assay, from the lowest: compound 1; then compounds 3 and 2 (each within the scatter of the next).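

In this assay the exchange of 1-methylethenyl for methoxy gives a 1.7-fold lower number from compound 2 to compound 3 (0.23 log units; within the scatter), so these two groups cannot be told apart at this aromatic carbon, even though they differ in their atoms and methoxy has no double bond outside aromatic rings. The comparison with ethyl gives a 17-fold higher number from compound 1 to compound 3 (1.22 log units; beyond the scatter), so two different replacements for ethyl now both give a much higher number, and the earlier drop in inhibition can no longer be pinned on the double bond of 1-methylethenyl alone. No measurement at hand explains why ethyl stands apart from these two groups at this position.

The compounds shown leave open how tightly the strong inhibition is tied to ethyl itself: methyl or a longer propyl chain at the same carbon could show whether chain length alone matters. Isopropyl, the saturated counterpart of 1-methylethenyl, could show whether the number seen for compound 2 goes with the branched carbon skeleton, while an amine or a chlorine would test the position with other kinds of atoms.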